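Methoxy to bromo swaps in a growth-inhibition series

This account rests on a few compounds, and the source may have more. Where it says the series, first, only, none or still open, it means among the compounds named here.

Measured compounds, with their values in a functional assay on HepG2 cells (Homo sapiens) for inhibition, read by MTT assay, with a stated time of 24 h; on this read-out lower numbers stand for stronger inhibition of growth and higher numbers for weaker inhibition of growth:
compound 1 `COc1ccccc1C(=O)n1c(-c2cn(C)c3ccccc23)nc2ccccc21` gives 31800 nM
compound 2 `Cn1cc(-c2nc3ccccc3n2C(=O)c2ccccc2Br)c2ccccc21` gives 68200 nM
compound 3 `COc1ccc2c(c1)c(-c1nc3ccccc3n1C(=O)c1ccccc1)cn2C` gives 37900 nM

Only one pair among these differs in a single place. That step is a 2.1-fold higher number from compound 1 to compound 2 (0.33 log units; beyond the scatter), and the change behind it is bromo in place of methoxy on an aromatic carbon. Compound 3 lies within the scatter of both compound 1 and compound 2, so no order among the three can be read from these numbers. Compound 3 and compound 1 share the same atoms joined differently; the difference between the two cores is not broken down here.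

Compound 4 `Cn1cc(-c2nc3ccccc3n2C(=O)c2ccccc2)c2cc(Br)ccc21` has not been measured. It differs from compound 3 by bromo in place of methoxy on an aromatic carbon. This is the same kind of change as the measured one, but not the same: in the measured pair the carbon sits on a six-membered aromatic ring of carbon only, ortho to a large group, whereas in compound 4 the ring is part of a fused system of two rings, and the carbon is meta to a fused ring and para to a fused ring.

For the measured compounds named here, for compound 4 a step of a 1.8-fold higher number from compound 3 to compound 4 (0.27 log units; within the scatter) is expected, because a 2.1-fold higher number from compound 1 to compound 2 (0.33 log units; beyond the scatter) was the only step of this kind seen, and the change of surroundings gives no reason to expect a different direction. The estimate for compound 4 in this assay is 70000 nM, expected to fall between 28000 nM and 175000 nM.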

Compound 4, concentration for 50% growth inhibition: 48100 nM
Compound 4: the middle estimate sits 1.5-fold (0.16 log units) above what was measured; the measured number falls inside the stated range.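

In this assay, bromo in place of methoxy on the second core gives a 1.3-fold higher number from compound 3 to compound 4 (0.10 log units; within the scatter), a step that cannot be told from repeat scatter on its own. Set beside the earlier step on the other core, the change shows no separable dependence on the core: the same change on two cores in this assay, a 2.1-fold higher number (0.33 log units; beyond the scatter) from compound 1 to compound 2 and a 1.3-fold higher number (0.10 log units; within the scatter) from compound 3 to compound 4, 1.7-fold (0.23 log units) apart, within the scatter of two such steps. The swap can therefore be carried between these two cores without any detectable difference in its size, and both steps print a higher number, although only the earlier one lies beyond the scatter; this does not show that the two steps are equal, that the swap would read the same on a further core, or which of the differences between the two pairs, core or place of the change, would matter if a real gap exists.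

The compounds shown carry only methoxy or bromo at the changed carbons, so the behaviour of an amine, a carboxylic acid or a longer chain such as butoxy at those places remains open. Also open, from the compounds shown here alone, is whether any substituent at either place would move the number well beyond the scatter, since two steps of a single kind give no wider picture.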